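Same aryl swap twice: three limits and one estimate

The source may hold more compounds than are shown below. What is called first, only, known or untested is meant among the compounds shown, and "the series" means these compounds.

Compound 1 `Cc1ccc(-n2nncc2CN2C(=O)C3(C(C#N)=C(N)Oc4c3c3nc5ccccc5nc3c3ccccc43)c3ccccc32)cc1Cl` gives > 50000 nM in a functional assay on HepG2 cells (Homo sapiens) for antiproliferative activity, read by MTT assay, with a stated time of 48 h; a higher number here means a weaker inhibitor, a lower number a stronger inhibitor; this value is a limit of the assay, not a number.
Compound 2 `Cc1ccc(Cl)cc1-n1nncc1CN1C(=O)C2(C(C#N)=C(N)Oc3c2c2nc4ccccc4nc2c2ccccc32)c2ccccc21` gives > 50000 nM in this assay; this too is a limit.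
Compound 3 `Cc1ccc(-n2nncc2CN2C(=O)C3(C(C#N)=C(N)Oc4c(N)cc5nc6ccccc6nc5c43)c3ccccc32)cc1Cl` gives > 50000 nM in this assay; again only a limit.

Compound 1 and compound 2 differ by 5-chloro-2-methylphenyl in place of 3-chloro-4-methylphenyl on an aromatic nitrogen. The step that the two limits leave unreadable from compound 1 to compound 2 cannot be sized, since both values sit at the limit of > 50000 nM in this assay, at which 3 of the 3 values shown sit. How compound 3 differs from compound 1 is not broken down here. Compound 4 `Cc1ccc(Cl)cc1-n1nncc1CN1C(=O)C2(C(C#N)=C(N)Oc3c(N)cc4nc5ccccc5nc4c32)c2ccccc21` differs from compound 3 by 5-chloro-2-methylphenyl in place of 3-chloro-4-methylphenyl on an aromatic nitrogen, the same change as between compound 1 and compound 2.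

For compound 4 the expectation is a step of a number no higher from compound 3 to compound 4 (the limit leaves the size open) in this assay, which rests on compound 3 sitting at its limit > 50000 nM and on the same change leaving compound 1 and compound 2 both at the limit of > 50000 nM in this assay, at which 3 of the 3 values shown sit. Compound 4 is therefore expected to show 50000 nM, most likely reported again only as a limit.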

Compound 4, half-maximal inhibitory concentration: 17300 nM
For compound 4 the middle estimate is 2.9-fold (0.46 log units) above the measured one; measured number below the stated range.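

The change from 3-chloro-4-methylphenyl to 5-chloro-2-methylphenyl gives an at least 2.8-fold lower number from compound 3 to compound 4 (0.46 log units; beyond the scatter) in this assay, the only readable step shown. The same change on the core of compound 1 cannot be read, because both compounds of that pair stop at the limit of the assay: the limit of > 50000 nM in this assay, at which 3 of the 4 values shown sit. Going by these compounds, the swap can therefore lower the number on one core, but this does not show that the effect carries over from one core to the other, nor that the two cores respond differently, and the full size of the readable step stays unknown.

Both the chlorine and the methyl group shift together in this swap, so the compounds shown leave open which of the two shifts matters. They also leave open what an unsubstituted phenyl on that nitrogen would give, or a version of the aryl ring with a methoxy group in place of the methyl group.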